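The source may report more compounds than this note shows. Statements on the series, on what has been measured and on what is new or still open speak of the compounds shown alone.

In a functional assay on IMR-32 cells (Homo sapiens) for cytotoxicity, read by sulforhodamine B assay, with a stated time of 48 h (on this read-out lower numbers stand for stronger inhibition and higher numbers for weaker inhibition), so far
- compound 1 `C=CCOc1cc(Br)ccc1C(=O)c1cccnc1` gives 98000 nM
- compound 2 `C=CCOc1ccccc1C(=O)c1cccnc1` gives 44000 nM

Among the measured compounds shown here, compound 1 carries the higher number, and the one measured step is a 2.2-fold lower number from compound 1 to compound 2 (0.35 log units; beyond the scatter) with hydrogen in place of bromo on an aromatic carbon. Compound 3 `O=C(c1cccnc1)c1ccc(Br)cc1O` differs from compound 1 by hydrogen in place of allyl on an oxygen on an aromatic ring with hydrogen in place of allyl on an oxygen on an aromatic ring. For the measured compounds named here, the measured step concerns the bromo, so no measured step covers this change, and no direction can be drawn from the data. Only a small change is expected in this assay as the working assumption. The expected step is a 1.2-fold lower number from compound 1 to compound 3 (0.09 log units; within the scatter) on this basis. For compound 3 the estimated value is 80000 nM with an expected range from 25000 nM to 220000 nM as the working figures.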

Compound 3, half-maximal inhibitory concentration: 89000 nM
Compound 3: the middle estimate sits 1.1-fold (0.05 log units) below what was measured; the measured number falls inside the stated range.
By their numbers in this assay, from the lowest: compound 2; then compounds 3 and 1 (each within the scatter of the next).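

In this assay, the change from allyloxy to hydroxy on the bromo-bearing core gives a 1.1-fold lower number from compound 1 to compound 3 (0.04 log units; within the scatter) and stays within the scatter. Among the compounds shown here, at this oxygen, hydrogen in place of allyl therefore leaves the number essentially unchanged, a first reading for this position, as the earlier step concerned only the bromo. No evidence on the cause of this result is available.

Going by these compounds, it remains open whether hydroxy behaves the same way on the core of compound 2. On these data alone, it is also open whether an amine or a longer chain at this oxygen would shift the number beyond the scatter.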